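The source may report more compounds than this note shows. Statements on the series, on what has been measured and on what is new or still open speak of the compounds shown alone.

In a functional assay on A549 cells (Homo sapiens) for antiproliferative activity, read by sulforhodamine B assay, with a stated time of 72 h (on this read-out higher numbers stand for weaker inhibition and lower numbers for stronger inhibition), compound 2 `COc1ncc(-c2ccc3ncnc(Nc4ccc(OCCO)nc4)c3c2)cc1NS(=O)(=O)c1ccc(F)cc1F` gives 4120 nM, the lowest of the two numbers recorded so far. Its nearest neighbour is compound 1 `COc1ncc(-c2ccc3ncnc(Nc4ccc(OCCO)c(Cl)c4)c3c2)cc1NS(=O)(=O)c1ccc(F)cc1F`, which in this assay gives 5980 nM; the step of a 1.5-fold lower number from compound 1 to compound 2 (0.16 log units; within the scatter) lies within the scatter, so the two compounds cannot be told apart on these numbers.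

Compound 3 `COc1cc(Nc2ncnc3ccc(-c4cnc(OC)c(NS(=O)(=O)c5ccc(F)cc5F)c4)cc23)ccc1OCCO` is the next compound to be measured. It differs from compound 2 in one place: 4-(2-hydroxyethoxy)-3-methoxyphenyl in place of 6-(2-hydroxyethoxy)pyridin-3-yl on a nitrogen on an aromatic ring. Among the compounds with values here, the only measured step that touches the same place is the one from compound 1 to compound 2, which exchanged the 3-chloro-4-(2-hydroxyethoxy)phenyl group for the 6-(2-hydroxyethoxy)pyridin-3-yl group and moved the number by a 1.5-fold lower number from compound 1 to compound 2 (0.16 log units; within the scatter), within the scatter. The change now considered brings a different aromatic group of carbon only to the same nitrogen. On this single, small precedent the expected step in this assay is a 1.2-fold higher number from compound 2 to compound 3 (0.08 log units; within the scatter), meaning no movement beyond the scatter in either direction. Compound 3 is therefore expected to give about 5000 nM, with a likely range from 2200 nM to 11000 nM.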

Compound 3, half-maximal inhibitory concentration: 3760 nM
Compound 3: the middle estimate sits 1.3-fold (0.12 log units) above what was measured; measured number inside the range.
By their numbers in this assay, from the lowest: compounds 3, 2 and 1 (each within the scatter of the next).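

In this assay, the 4-(2-hydroxyethoxy)-3-methoxyphenyl group in place of the 6-(2-hydroxyethoxy)pyridin-3-yl group gives a 1.1-fold lower number from compound 2 to compound 3 (0.04 log units; within the scatter), so at this place on the nitrogen, an aromatic ring of carbon only and one with a hetero atom cannot be told apart on these numbers. Within the data shown here, compounds 1 and 3 also allow the first direct comparison of two groups on an aromatic carbon: methoxy in place of chloro gives a 1.6-fold lower number from compound 1 to compound 3 (0.20 log units; within the scatter), which is again within the scatter, so all three groups tried at this place give numbers that cannot be separated. Nothing available explains why these changes leave the number within the scatter.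

On these data alone, all three compounds carry the 2-hydroxyethoxy group, so it remains open whether an amine or a carboxylic acid in place of its hydroxyl group, or a longer chain, would move the number beyond the scatter. As far as these compounds go, it also remains open whether a larger group in place of the chloro or methoxy group, such as a phenyl ring, would do so.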